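One Methyl Fewer on a Saturated Ring Carbon

A few compounds are considered here, and "the series" means these few. Any claim that something is new, unique, unknown or untested is made for them only; others in the source may bear on it.

Measured compounds:
compound 1 `CC1(C)CC(=O)c2s/c(=N/C3CCCCC3)oc2C1` — 11300 nM
compound 2 `CC(C)C1CC(=O)c2s/c(=N/c3ccc(F)cc3)oc2C1` — 3670 nM
compound 3 `CC1(C)CC(=O)c2s/c(=N/c3c(Cl)cc(Cl)cc3Cl)oc2C1` — > 30000 nM

Of the compounds shown here, three built on a shared core have been tested in a functional assay on ACHN cells (Homo sapiens) for antiproliferative activity, read by sulforhodamine B assay; on this read-out higher numbers stand for weaker inhibition of growth and lower numbers for stronger inhibition of growth. Compound 1 gives 11300 nM. Compound 2 gives 3670 nM. Compound 3 returns no number at all, only a limit of > 30000 nM. That is the limit of > 30000 nM in this assay, at which 1 of the 3 values shown sits, so compound 3 stands at the edge of what this assay resolves, weaker than anything it can put a figure to.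

Compound 4 `CC1CC(=O)c2s/c(=N/c3c(Cl)cc(Cl)cc3Cl)oc2C1` differs from compound 3 in a single place: hydrogen in place of methyl on a saturated ring carbon. Going by the values given here, no two measured compounds differ in exactly this way, so the size of the step has to be guessed. Compound 1 and compound 2 differ from compound 3 in more than one place and cannot isolate the methyl. The expected step in this assay is small, none beyond the scatter, in either direction. Compound 4 is therefore expected near the limit as well, estimated at 30000 nM, with a range from 10000 nM to 100000 nM. The step this estimate implies is a number no higher from compound 3 to compound 4 (the limit leaves the size open).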

Compound 4, concentration for 50% growth inhibition: > 30000 nM
Compound 4: a limit, no number; the forecaster's own chance of this, stated with the estimate: 60%; the middle value lies on the limit itself.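

No step can be read from compound 3 to compound 4, because each returns only a limit and not a number: the limit of > 30000 nM in this assay, at which 2 of the 4 values shown sit. The compounds shown leave open whether hydrogen in place of methyl on a saturated ring carbon changes growth inhibition at all.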